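Swapping a pyrazole for phenyl on an amide side chain

The source may report more compounds than this note shows. Statements on the series, on what has been measured and on what is new or still open speak of the compounds shown alone.

Compound 1 `CCN(Cc1cc[nH]n1)C(=O)COc1ccc(C)cc1` was tested in an assay on HEK293 cells for agonist activity at transient receptor potential cation channel subfamily M member 8 (Homo sapiens), read by fluorescence and calcium flux, with a stated time of 15 min (a higher number here means that more compound is needed for the effect, a lower number that less compound is needed), and came out as "not active" (no number reported), so no single number places it on the scale. Two related compounds give numbers: compound 2 `CCN(Cc1cccs1)C(=O)COc1ccc(C(F)(F)F)cc1` gives 236 nM, and compound 3 `Cc1ccc2oc(C(=O)N(Cc3cccs3)c3ccn[nH]3)cc2c1` gives 40 nM. Compound 4 `CCN(Cc1ccccc1)C(=O)COc1ccc(C)cc1` has not yet been measured. It differs from compound 1 in one place: phenyl in place of 1H-pyrazol-3-yl on a saturated chain carbon bound to an amide-type nitrogen. With no numeric value for compound 1, no step size can be read off here; the change is expected to move toward a measurable value, since compound 2, which also carries an aromatic ring on that chain carbon, gives 236 nM. Compound 4 is expected to give about 5000 nM, in a range from 500 nM to 50000 nM.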

Compound 4, half-maximal effective concentration: 1880 nM
The estimate for compound 4 lay 2.7-fold (0.42 log units) above the measured number; low and high end bracket the measured number.
By their numbers in this assay, from the lowest: compound 3; then compound 2; then compound 4.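

Among the compounds shown here, compound 1 has no number on the scale, so no step to compound 4 can be read. The compounds shown leave open how far phenyl in place of 1H-pyrazol-3-yl moves the value by itself. No measurement shown here offers an explanation for the result.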